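The source may hold more compounds than are shown below. What is called first, only, known or untested is meant among the compounds shown, and "the series" means these compounds.

Compound 1 `CCn1c(CNc2ccccc2)nnc1SCC(=O)Nc1ccc(C(=O)NC)cc1` was tested in an assay on isolated protein for inhibition of long-chain fatty acid transport protein 1 (Homo sapiens); on this read-out higher numbers stand for weaker inhibition and lower numbers for stronger inhibition. For compound 1 only a limit is known, not a number: it gives > 1000 nM, which is the limit of > 1000 nM in this assay, at which 1 of the 3 values shown sits. Two further compounds have been measured. Compound 2 `CCOC(=O)c1ccc(NC(=O)CSc2nnc(CSCc3ccccc3)n2CC)cc1` gives 7600 nM in this assay. Compound 3 `CC/C(=N/O)c1ccc2oc(CSc3nnc(CNc4ccccc4)n3CC)nc2c1` gives 260 nM in this assay. Compound 4 `CCn1c(CNc2ccccc2)nnc1SCC(=O)Nc1ccc(Cl)cc1` has not yet been measured; it differs from compound 1 by chloro in place of methylcarbamoyl on an aromatic carbon. No measured pair of compounds shows the effect of this change, so its size cannot be read from the numbers shown. Compound 4 is therefore expected to land at a value of the same order, a step that the limit leaves unreadable from compound 1 to compound 4 that need not exceed the usual scatter. The estimate for compound 4 is 3000 nM, within a range from 700 nM to 15000 nM.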

Compound 4, half-maximal inhibitory concentration: > 1000 nM
Compound 4 gave a limit, no number; the forecaster's own chance of this, stated with the estimate: 40%; the middle value does not contradict the limit.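

Compound 1 and compound 4 each give only a limit, not a number, so no step between them can be read: the limit of > 1000 nM in this assay, at which 2 of the 4 values shown sit.

The compounds shown leave open whether chloro in place of methylcarbamoyl changes inhibition at all, and in which direction.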